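This account rests on a few compounds, and the source may have more. Where it says the series, first, only, none or still open, it means among the compounds named here.

Compound 1 `O=[N+]([O-])c1ccc(CN2CCC(n3cc(CC(OCc4cc(-c5ccccc5)no4)c4ccc(Br)cc4)nn3)CC2)cc1`, 3000 nM in a functional assay on MDA-MB-468 cells (Homo sapiens) for cytotoxicity, with a stated time of 48 h; a higher number here means a weaker inhibitor, a lower number a stronger inhibitor; compound 2 `COc1cccc(-c2cc(COC(Cc3cn(C4CCN(Cc5ccc([N+](=O)[O-])cc5)CC4)nn3)c3ccc(Br)cc3)on2)c1`, > 25000 nM in this assay.

Compound 2 sits at the limit of this assay, (the limit of > 25000 nM in this assay, at which 1 of the 2 values shown sits), so only a bound is known for it. Compound 3 `O=[N+]([O-])c1ccc(CN2CCC(n3cc(CC(OCc4cc(-c5ccccc5F)no4)c4ccc(Br)cc4)nn3)CC2)cc1` differs from compound 2 by 2-fluorophenyl in place of 3-methoxyphenyl on an aromatic carbon. Among the compounds with values here, the one measured step touching this aryl group is an at least 8.3-fold higher number from compound 1 to compound 2 (0.92 log units; beyond the scatter), which came from adding the methoxy. Within the data shown here, since compound 3 drops that methoxy, it is expected to move back toward compound 1; the fluorine has no measured precedent here. For compound 3 the estimate is 4500 nM, ranging 1500 nM to 15000 nM, an expected at least 5.5-fold lower number from compound 2 to compound 3 (0.74 log units; beyond the scatter).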

Compound 3, half-maximal inhibitory concentration: 4000 nM
The estimate for compound 3 lay 1.1-fold (0.05 log units) above the measured number; the range from low to high includes it.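

Replacing 3-methoxyphenyl with 2-fluorophenyl gives an at least 6.2-fold lower number from compound 2 to compound 3 (0.79 log units; beyond the scatter), so the loss seen with the methoxy does not extend to every substituted phenyl at this place. Compound 2 stands at a limit of this assay: the limit of > 25000 nM in this assay, at which 1 of the 3 values shown sits. Fluoro in place of hydrogen gives a 1.3-fold higher number from compound 1 to compound 3 (0.12 log units; within the scatter), so this phenyl takes the fluorine with no change beyond the scatter.

Still open, from the compounds shown here alone, is whether the methoxy itself or its place on the phenyl goes with the loss in compound 2. Going by these compounds, how a phenyl bearing an amine or a carboxylic acid would read here also remains open.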